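The compounds below may be only part of what the source reports. "The series", "measured", "known", "first", "only" and "open" are said of these compounds alone.

Measured so far:
compound 1, `CNC(=O)c1cc(Oc2cccc(NC(=S)Nc3ccc(Cl)cc3Cl)c2)ccn1`, in a functional assay on PC-3 cells (Homo sapiens) for cytotoxicity, read by MTT assay, with a stated time of 48 h (a higher number here means a weaker inhibitor, a lower number a stronger inhibitor), compound 1 gives 37800 nM
compound 2, `O=C(NC1CCCCC1)c1cc(Oc2cccc(NC(=S)Nc3ccc(F)c(F)c3)c2)ccn1`, in this assay compound 2 gives 8100 nM

Compound 1 holds the highest number of the two measured; its nearest neighbour is compound 2, whose lower number lies beyond the scatter. Among the compounds with values here, compound 2 differs from compound 1 in two places at once, so the pair says nothing about either change on its own, and no single-change step between measured compounds exists in this set.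

Compound 3 `CNC(=O)c1cc(Oc2cccc(NC(=S)Nc3cccc(C(F)(F)F)c3)c2)ccn1` is not yet measured. It differs from compound 1 in one place: 3-(trifluoromethyl)phenyl in place of 2,4-dichlorophenyl on an amide-type nitrogen. Within the data shown here, with no anchored step available, the size of the move in this assay cannot be calibrated from the data; the working expectation is a modest shift toward a lower number, of a size that may well sit within the scatter, because compound 1 starts from 37800 nM and both measured numbers lie in the same high region. Compound 3 is estimated at 25000 nM, with a range from 8000 nM to 80000 nM. The step expected from compound 1 to compound 3 is a 1.5-fold lower number from compound 1 to compound 3 (0.18 log units; within the scatter).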

Compound 3, half-maximal inhibitory concentration: 24500 nM
The estimate for compound 3 lay 1.0-fold (0.01 log units) above the measured number; the range from low to high includes it.
By their numbers in this assay, from the lowest: compound 2; then compounds 3 and 1 (each within the scatter of the next).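

In this assay the exchange of 2,4-dichlorophenyl for 3-(trifluoromethyl)phenyl gives the series its first single-change step: a 1.5-fold lower number from compound 1 to compound 3 (0.19 log units; within the scatter). On this amide-type nitrogen, whose other neighbour is the thiocarbonyl carbon, replacing one substituted phenyl with the other therefore does not separate compound 1 from compound 3 in this read-out, although two chlorine atoms leave and a trifluoromethyl group enters. No measurement at hand bears on the reason for this result.

From the compounds shown here alone, it remains open whether any group on this nitrogen can move the number beyond the scatter, and an unsubstituted phenyl, a 4-methoxyphenyl or a simple hexyl chain would test the point more widely than these two substituted phenyl groups do. The other end of the molecule is also unresolved, since compound 2 carries its changes in two places at once, so the effect of replacing the methyl on the amide with cyclohexyl, or with a carboxylic acid in place of the whole amide, cannot be read from the compounds shown.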